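The source may report more compounds than this note shows. Statements on the series, on what has been measured and on what is new or still open speak of the compounds shown alone.

Measured so far:
- compound 1 `NC(=O)c1cc(Br)ccc1NC(=O)/C=C/c1ccccc1`: 62.4%
- compound 2 `NC(=O)c1cc(Br)ccc1NC(=O)/C=C/c1ccccc1Cl`: 59%
- compound 3 `NC(=O)c1cc(I)ccc1NC(=O)/C=C/c1ccccc1`: 74.5%

In a functional assay on K562 cells (Homo sapiens) for antiproliferative activity, read by trypan blue exclusion, with a stated time of 48 h, tested at 10 uM (a lower number here means less inhibition of growth, a higher number more inhibition of growth at the concentration tested), compound 3 stands highest of the three, and the iodo in place of bromo change gave a number 12.1 percentage points higher from compound 1 to compound 3 (beyond the scatter). Compound 4 `NC(=O)c1cc(I)ccc1NC(=O)/C=C/c1ccccc1Cl` differs from compound 3 by one change, chloro in place of hydrogen on an aromatic carbon. That same change has been measured once, on the bromo compounds, where it gave a number 3.4 percentage points lower from compound 1 to compound 2 (within the scatter). One such step is thin evidence, but it points to little movement when the change is repeated on the iodo compound. The expected step is a number 3.5 percentage points lower from compound 3 to compound 4 (within the scatter), which would stay within the scatter. For compound 4 the estimate is 71%, with an expected range of 60% to 82%.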

Compound 4, percent growth inhibition at one concentration: 74.1%
Estimate against measurement, compound 4: 3.1 percentage points below, and the stated range covers the measured number.
By their numbers in this assay, from the lowest: compounds 2 and 1 (each within the scatter of the next); then compounds 4 and 3 (each within the scatter of the next).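

Chloro in place of hydrogen, phenyl to 2-chlorophenyl, now gives a number 0.4 percentage points lower from compound 3 to compound 4 (within the scatter) on the iodo core, so a second core also shows no step beyond the scatter at this place: the same change on two cores in this assay, a number 3.4 percentage points lower (within the scatter) from compound 1 to compound 2 and a number 0.4 percentage points lower (within the scatter) from compound 3 to compound 4, 3 percentage points apart, within the scatter of two such steps.
Iodo in place of bromo, first seen without the chloro, also holds with it present, giving a number 15.1 percentage points higher from compound 2 to compound 4 (beyond the scatter), so the two changes appear independent across these four compounds: the same change on two cores in this assay, a number 12.1 percentage points higher (beyond the scatter) from compound 1 to compound 3 and a number 15.1 percentage points higher (beyond the scatter) from compound 2 to compound 4, 3 percentage points apart, within the scatter of two such steps.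

On these data alone, whether an amine or a methoxy group at this same place would move the number remains open. So does the effect of fluoro in place of iodo.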